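The source may report more compounds than this note shows. Statements on the series, on what has been measured and on what is new or still open speak of the compounds shown alone.

Compound 3 `Cc1n[nH]cc1Nc1nc(N)c2c(C#N)c(N3CCC[C@H]3C)n(C)c2n1` gives 27 nM in an assay on isolated protein for inhibition of Leucine-rich repeat serine/threonine-protein kinase 2 variant G2019S (Homo sapiens), read by TR-FRET and LanthaScreen, with stated times of 50 min and 30 min, in the presence of a further agent that is not named here (a higher number here means a weaker inhibitor, a lower number a stronger inhibitor), the lowest of the three numbers shown, though each neighbour sits within the scatter of it. Compound 1 `Cc1nn(CC(C)(C)O)cc1Nc1nc(N)c2c(C#N)c(N3CCC[C@H]3C)n(C)c2n1` gives 42 nM in this assay, and compound 2 `Cc1c(Nc2nc(N)c3c(C#N)c(N4CCC[C@H]4C)n(C)c3n2)cnn1C1COC1` gives 37 nM in this assay. Both measured steps onto compound 3 remove a group from the aromatic nitrogen and neither reaches beyond the scatter: a 1.6-fold lower number from compound 1 to compound 3 (0.19 log units; within the scatter) and a 1.4-fold lower number from compound 2 to compound 3 (0.14 log units; within the scatter). Compound 4 `Cc1nn(C)cc1Nc1nc(N)c2c(C#N)c(N3CCC[C@H]3C)n(C)c2n1` now puts the smallest group back at that position: methyl in place of hydrogen on an aromatic nitrogen. Because a 1.6-fold lower number from compound 1 to compound 3 (0.19 log units; within the scatter) and a 1.4-fold lower number from compound 2 to compound 3 (0.14 log units; within the scatter) stayed flat for far larger groups, no step beyond the scatter in either direction is expected for this change in this assay. For compound 4 the expected value is 30 nM, range 15 nM to 60 nM, meaning a 1.1-fold higher number from compound 3 to compound 4 (0.05 log units; within the scatter) is expected.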

Compound 4, half-maximal inhibitory concentration: 30 nM
Beside the measured number, compound 4's estimate shows no gap at the digits printed, within the range that was stated.
By their numbers in this assay, from the lowest: compounds 3, 4, 2 and 1 (each within the scatter of the next).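

In this assay, methyl on the aromatic nitrogen gives no step beyond the scatter from the bare nitrogen: a 1.1-fold higher number from compound 3 to compound 4 (0.05 log units; within the scatter). The smallest group also sits within the scatter of the two larger ones, with a 1.2-fold lower number from compound 2 to compound 4 (0.09 log units; within the scatter) and a 1.4-fold lower number from compound 1 to compound 4 (0.15 log units; within the scatter), although compound 2 also carries its methyl at a different ring position. Nothing at hand explains this flat response.

On these data alone, whether a basic amine or a carboxylic acid on this nitrogen would stay within the scatter remains open. So does the outcome of replacing the ring methyl with ethyl.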